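Fluorine Added to a Compound That Showed No Inhibition

This account rests on a few compounds, and the source may have more. Where it says the series, first, only, none or still open, it means among the compounds named here.

Measured so far:
compound 1 `Cc1nnc(SCC(=O)N/N=c2/scc(-c3ccccc3)n2-c2ccccc2)s1`: > 200 ug/mL
compound 2 `O=C(CSc1nnnn1-c1ccccc1)N/N=c1/scc(-c2ccc(Br)cc2)n1-c1ccccc1`: 21 ug/mL

In a functional assay on C6 cells (Rattus norvegicus) for cytotoxicity, read by MTT assay, with a stated time of 24 h (on this read-out higher numbers stand for weaker inhibition and lower numbers for stronger inhibition), compound 1 gives > 200 ug/mL, which is a limit of the assay and not a number. In this assay compound 2 gives 21 ug/mL. Compound 3 `Cc1nnc(SCC(=O)N/N=c2/scc(-c3ccc(F)cc3)n2-c2ccccc2)s1` differs from compound 1 by one change, (fluoro in place of hydrogen on an aromatic carbon), fluoro in place of hydrogen on an aromatic carbon. Within the data shown here, no measured pair shows this change on its own. Because compound 1 sits at the limit of > 200 ug/mL in this assay, at which 1 of the 2 values shown sits, the step is expected to stay within scatter, a number no higher from compound 1 to compound 3 (the limit leaves the size open). Compound 3 is therefore expected to give about 200 ug/mL, somewhere between 100 ug/mL and 400 ug/mL.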

Compound 3, half-maximal inhibitory concentration: 27.3 ug/mL
Estimate against measurement, compound 3: 7.3-fold (0.86 log units) above; the measured number lies below the stated range.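

Swapping phenyl for 4-fluorophenyl, a change of one atom, gives an at least 7.3-fold lower number from compound 1 to compound 3 (0.86 log units; beyond the scatter) in this assay, the first sign that this aromatic carbon affects the read-out. Compound 1 gives > 200 ug/mL, which is a limit of the assay and not a number. The full size of the step therefore stays unknown, because it starts from a limit: the limit of > 200 ug/mL in this assay, at which 1 of the 3 values shown sits.

On these data alone, what remains open is whether fluoro is special here, or whether chloro, methoxy or an amine on the same carbon would do the same. As far as these compounds go, whether fluoro has this effect on other compounds also remains open.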